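The source may hold more compounds than are shown below. What is called first, only, known or untested is meant among the compounds shown, and "the series" means these compounds.

Series notes. Compound 1 `COc1cc(-c2cc(/C=C/C(=O)c3ccc(Cl)c(Cl)c3)[nH]n2)cc(OC)c1OC` carries the 3,4-dichlorophenyl on the carbonyl carbon. In a functional assay on K562 cells (Homo sapiens) for cytotoxicity, read by sulforhodamine B assay, with a stated time of 48 h, tested at 1 uM (a lower number here means a stronger effect, a higher number a weaker effect of the compound at the concentration tested), compound 1 gives 101%, the highest number among the three measured compounds. Compound 2 `COc1ccc(-c2cc(/C=C/C(=O)c3cc(OC)c(OC)c(OC)c3)[nH]n2)cc1OC` gives 43% in this assay, and compound 3 `COc1ccc(-c2cc(/C=C/C(=O)c3ccc(N)cc3)[nH]n2)cc1` gives 58%; both numbers stand below that of compound 1 by amounts beyond the scatter. Compound 4 `COc1ccc(C(=O)/C=C/c2cc(-c3cc(OC)c(OC)c(OC)c3)n[nH]2)cc1OC` has not been measured. The change from compound 1 to compound 4 is 3,4-dimethoxyphenyl in place of 3,4-dichlorophenyl on a carbonyl carbon. Among the compounds with values here, no measured pair isolates this change, so the expectation rests only on compounds 2 and 3, which lack the 3,4-dichlorophenyl and give the lower numbers. The expected step of a number 46 percentage points lower from compound 1 to compound 4 (beyond the scatter) is a drop beyond the scatter. Compound 4 is therefore estimated at 55%, within 30% to 90%.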

Compound 4, a percentage reported as activity, at one concentration (the size of the read-out at that concentration, not a potency): 75%
Compound 4: the middle estimate sits 20 percentage points below what was measured; low and high end bracket the measured number.
By their numbers in this assay, from the lowest: compound 2; then compound 3; then compound 4; then compound 1.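

Within the data shown here, on the carbonyl carbon, 3,4-dimethoxyphenyl in place of 3,4-dichlorophenyl gives the first one-place reading in this assay, with a number 26 percentage points lower from compound 1 to compound 4 (beyond the scatter) as the step. With the rest of compound 1 unchanged, this position alone moves the number, though only modestly. No measurement on hand accounts for the step.

Going by these compounds, how a phenyl carrying a carboxylic acid or a single methoxy group would read at this carbonyl carbon remains open. So does whether the step would carry over to a different substitution on the rest of the core.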